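The compounds below may be only part of what the source reports. "The series", "measured", "known", "first", "only" and "open" are said of these compounds alone.

In a functional assay on MCF7 cells (Homo sapiens) for cytotoxicity, read by ELISA, with a stated time of 4 days (a higher number here means a weaker inhibitor, a lower number a stronger inhibitor), compound 1 (`Cc1ccc(-c2cc(-c3ccoc3)cc(-c3ccc(Cl)s3)n2)cc1`) gives 5340 nM and compound 2 (`Clc1ccc(-c2cc(-c3ccoc3)cc(-c3ccccc3Cl)n2)s1`) gives 7360 nM, so compound 2 stands within the scatter of compound 1. Compound 3 (`Clc1ccc(-c2cc(-c3ccoc3)cc(-c3ccc(Cl)s3)n2)cc1`) differs from compound 2 in one place: 4-chlorophenyl in place of 2-chlorophenyl on an aromatic carbon, with 4-chlorophenyl in place of 2-chlorophenyl next to the ring nitrogen. Among the measured compounds shown here, the only measured step that bears on this swap is a 1.4-fold higher number from compound 1 to compound 2 (0.14 log units; within the scatter), where 2-chlorophenyl took the place of 4-methylphenyl, and it stayed within the scatter. No step beyond the scatter is therefore expected in this assay. Compound 3 is estimated at 5500 nM, with an expected range of 2500 nM to 12000 nM. The expected change is a 1.3-fold lower number from compound 2 to compound 3 (0.13 log units; within the scatter).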

Compound 3, half-maximal inhibitory concentration: 2600 nM
Beside the measured number, compound 3's estimate is 2.1-fold (0.33 log units) above it; measured number inside the range.
By their numbers in this assay, from the lowest: compound 3; then compounds 1 and 2 (each within the scatter of the next).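

Among the compounds shown here, at this place, next to the ring nitrogen, 4-chlorophenyl in place of 2-chlorophenyl gives the first step beyond the scatter in this assay: a 2.8-fold lower number from compound 2 to compound 3 (0.45 log units; beyond the scatter). Chloro in place of methyl on the phenyl group also counts, with a 2.1-fold lower number from compound 1 to compound 3 (0.31 log units; beyond the scatter). Both steps are modest, but they show that this position responds to small changes in the group it carries. No evidence here bears on the reason for either step. The compounds shown leave open how an amine or a carboxylic acid in place of the chloro of the 4-chlorophenyl group would read.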